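This account rests on a few compounds, and the source may have more. Where it says the series, first, only, none or still open, it means among the compounds named here.

Measured compounds:
compound 1, `CCN(Cc1ccccc1)c1cccc(C(=O)N2CCc3ccc(OS(N)(=O)=O)cc3C2)c1`, which in an assay on HEK293 cells for inhibition of Steryl-sulfatase (Homo sapiens), tested at 0.1 uM (on this read-out lower numbers stand for a weaker effect and higher numbers for a stronger effect at the one concentration tested), gives 17.3%
compound 2, `NS(=O)(=O)Oc1ccc2c(c1)CN(C(=O)c1cccc(N3CCCCC3)c1)CC2`, which in this assay gives 1%

Within the data shown here, compound 2 stands lowest of the two numbers measured so far; its only neighbour is compound 1, and the one step between them, a number 16.3 percentage points lower from compound 1 to compound 2 (beyond the scatter), was beyond the scatter but modest in size. Compound 3, `CN(C)CCN(CCN(C)C)c1cccc(C(=O)N2CCc3ccc(OS(N)(=O)=O)cc3C2)c1`, has not yet been measured. It differs from compound 2 in one place: bis(2-(dimethylamino)ethyl)amino in place of piperidin-1-yl on an aromatic carbon. Among the measured compounds shown here, the only measured step that bears on this change is the one from compound 1 to compound 2, where a different group on the same aromatic carbon lowered the read-out. That step does not involve the group that enters here, so it gives little guidance beyond showing that this position can move the number modestly. For compound 3 the expected result is 6% (range 0% to 22%), so the estimated step is a number 5 percentage points higher from compound 2 to compound 3 (within the scatter), not expected to go beyond the scatter.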

Compound 3, a percentage reported as inhibition, at one concentration (the size of the read-out at that concentration, not a potency): 0%
Beside the measured number, compound 3's estimate is 6 percentage points above it; the range from low to high includes it.
By their numbers in this assay, from the lowest: compounds 3 and 2 (each within the scatter of the next); then compound 1.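

In this assay, the step to the open-chain bis(2-(dimethylamino)ethyl)amino group, a number 1 percentage points lower from compound 2 to compound 3 (within the scatter), shows that replacing the piperidin-1-yl ring with this larger group leaves the read-out unchanged within the scatter. Both numbers lie close to zero, so this comparison cannot separate these two groups at the one concentration tested. The second step, a number 17.3 percentage points lower from compound 1 to compound 3 (beyond the scatter), shows that compound 1, with its benzyl(ethyl)amino group, now stands apart from two quite different groups at this aromatic carbon. Nothing available explains these results.

The compounds shown leave open whether the benzyl part or the ethyl part of compound 1 matters more. A benzylamino group without the ethyl, or a longer phenylethyl chain on the nitrogen, would bear directly on that question.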